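The compounds below may be only part of what the source reports. "The series", "measured", "known", "first", "only" and "open" are said of these compounds alone.

Measured in a physicochemical assay for metabolic stability, read by LC-MS, with a stated time of 38 days, tested at 10 mM; a lower number here means that less of the compound is left, a higher number that more of the compound is left:
Compound 1 `Cc1ccc(-c2cc(C(=O)O)ccn2)o1`: 85%
Compound 2 `Cc1ccc(-c2cc(C(=O)Nc3nnc(-c4ccncc4)s3)c3ccccc3c2)o1`: 25%

Compound 2 has the lower of these two numbers. At 25%, compound 2 lies beyond the scatter below the other compound. Compound 3 `O=C(Nc1nnc(-c2ccncc2)s1)c1cc(-c2ccco2)cc2ccccc12` differs from compound 2 in one place: hydrogen in place of methyl on an aromatic carbon. In words, this is hydrogen in place of methyl on an aromatic carbon, turning 5-methylfuran-2-yl into furan-2-yl. For the measured compounds named here, no measured pair shows this change, and it is a small one, so no step beyond the scatter is expected in this assay. The estimated step of a number 3 percentage points higher from compound 2 to compound 3 (within the scatter) stays within the scatter. For compound 3 the expected value is 28%, with an estimated range of 10% to 50%.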

Compound 3, percent of the compound remaining: 0%
Estimate against measurement, compound 3: 28 percentage points above; the measured number lies below the stated range.
By their numbers in this assay, from the lowest: compound 3; then compound 2; then compound 1.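

In this assay, turning 5-methylfuran-2-yl into furan-2-yl gives a number 25 percentage points lower from compound 2 to compound 3 (beyond the scatter), so this small change is not neutral here. The position, on an aromatic carbon next to the ring oxygen, can therefore move the number beyond the usual scatter, although only one heavy atom leaves. Nothing available here accounts for this step.

As far as these compounds go, what an ethyl group, a chlorine atom or an amine would give at this same place remains open. So does whether hydrogen in place of methyl would give a similar step on a different core.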